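Removing the aminomethyl group from compound 1

This account rests on a few compounds, and the source may have more. Where it says the series, first, only, none or still open, it means among the compounds named here.

In an ADME assay on microsomes from liver (Rattus norvegicus) for metabolic stability, read by LC-MS, tested at 10 uM (a lower number here means that the compound disappears faster, a higher number that the compound lasts longer), compound 1 `NCc1ccc(NC(=O)N(CCCCO)Cc2ccc(C(=O)NO)cc2)cc1` gives 1.95 h and compound 2 `CCCCN(Cc1ccc(C(=O)NO)cc1)C(=O)Nc1ccc(CN)cc1` gives 2.88 h as its half-life, two values within the scatter of each other. Compound 3 `O=C(NO)c1ccc(CN(CCCCO)C(=O)Nc2ccccc2)cc1` differs from compound 1 by hydrogen in place of aminomethyl on an aromatic carbon with hydrogen in place of aminomethyl on an aromatic carbon. Going by the values given here, no measured step tests this change: the only one (a 1.5-fold higher number from compound 1 to compound 2 (0.17 log units; within the scatter)) puts hydrogen in place of hydroxy on a saturated chain carbon. No shift beyond the scatter is therefore expected, and the estimated step (a 1.1-fold lower number from compound 1 to compound 3 (0.03 log units; within the scatter)) has no firm direction. The estimated half-life of compound 3 is 1.8 h (range 0.7 h to 4 h).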

Compound 3, half-life: 3.3 h
The estimate for compound 3 lay 1.8-fold (0.26 log units) below the measured number; low and high end bracket the measured number.
By their numbers in this assay, from the lowest: compounds 1, 2 and 3 (each within the scatter of the next).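

In this assay, replacing aminomethyl with hydrogen on the aromatic carbon para to a large group gives a 1.7-fold higher number from compound 1 to compound 3 (0.23 log units; within the scatter), so this change stays within the scatter. The earlier step bore only on the hydroxy on the saturated chain and said nothing about this aromatic carbon. No measured evidence bears on this result.

As far as these compounds go, whether a carboxylic acid or a longer amine chain at this carbon would also stay within the scatter remains open. So does the effect of the same change on the butyl chain of compound 2.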